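Swapping a ring at the core of compound 2

A few compounds are considered here, and "the series" means these few. Any claim that something is new, unique, unknown or untested is made for them only; others in the source may bear on it.

Of the compounds shown here, two with a shared core have been tested in a functional assay on K562 cells (Homo sapiens) for cytotoxicity, in the presence of a further agent that is not named here; a higher number here means a weaker inhibitor, a lower number a stronger inhibitor. Compound 1 `Clc1cccc(-c2cc(-c3ccc(Cl)o3)cc(-c3cccs3)n2)c1` gives 19800 nM, and compound 2 `Clc1ccc(-c2cc(-c3ccsc3)nc(-c3ccccn3)c2)o1` gives 21900 nM; the two numbers lie within the scatter of each other, so neither can be called the stronger inhibitor. Compound 3 `Cc1ccccc1-c1cc(-c2ccc(Cl)o2)cc(-c2ccsc2)n1` differs from compound 2 in one place: 2-methylphenyl in place of pyridin-2-yl on an aromatic carbon. For the measured compounds named here, no measured pair shows what this kind of change does, so no step beyond the scatter is expected in this assay. The expected step of a 1.1-fold lower number from compound 2 to compound 3 (0.04 log units; within the scatter) is small. Compound 3 is estimated at 20000 nM, between 7000 nM and 55000 nM.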

Compound 3, half-maximal inhibitory concentration: 18400 nM
Compound 3: the middle estimate sits 1.1-fold (0.04 log units) above what was measured; the measured number falls inside the stated range.
By their numbers in this assay, from the lowest: compounds 3, 1 and 2 (each within the scatter of the next).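

Putting 2-methylphenyl in place of pyridin-2-yl gives a 1.2-fold lower number from compound 2 to compound 3 (0.08 log units; within the scatter) in this assay as the measure of this change. So on this aromatic carbon, next to the ring nitrogen, a six-membered ring of carbon only with no hydrogen-bond acceptor reads the same as pyridin-2-yl, within the scatter. Nothing measured here explains this result. Still open, on these data alone, is whether a small group such as an amine or a carboxylic acid on this carbon would shift the number beyond the scatter.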